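Pentafluoroethyl for pentafluorosulfanyl on the anilide ring

The compounds below may be only part of what the source reports. "The series", "measured", "known", "first", "only" and "open" are said of these compounds alone.

Compound 1 `CC(O)(COc1cc(C(F)(F)F)cc(C(F)(F)F)c1)C(=O)Nc1cccc(S(F)(F)(F)(F)F)c1` and compound 2 `CC(O)(COc1cccc(S(F)(F)(F)(F)F)c1)C(=O)Nc1cc(C(F)(F)F)cc(C(F)(F)F)c1` are built from the same atoms joined differently; the difference between the two cores is not broken down here. In a functional assay on LNCaP cells (Homo sapiens) for antiproliferative activity, read by propidium iodide staining, with a stated time of 96 h (a higher number here means a weaker inhibitor, a lower number a stronger inhibitor), compound 1 gives 2800 nM, and compound 2 gives 3000 nM, the two lying within the scatter of each other. Compound 3 `CC(O)(COc1cccc(C(F)(F)C(F)(F)F)c1)C(=O)Nc1cc(C(F)(F)F)cc(C(F)(F)F)c1` differs from compound 2 by a group of 7 heavy atoms (2 carbon, 5 fluorine; no ring) in place of a group of 6 heavy atoms (5 fluorine, 1 sulfur; no ring), on an aromatic carbon. In this assay compound 3 gives 4400 nM, a step of a 1.5-fold higher number from compound 2 to compound 3 (0.17 log units; within the scatter). Compound 4 `CC(O)(COc1cc(C(F)(F)F)cc(C(F)(F)F)c1)C(=O)Nc1cccc(C(F)(F)C(F)(F)F)c1` carries the same change on the core of compound 1, namely (a group of 7 heavy atoms (2 carbon, 5 fluorine; no ring) in place of a group of 6 heavy atoms (5 fluorine, 1 sulfur; no ring), on an aromatic carbon), at a place described in the same words. The step expected for this change is a 1.5-fold higher number from compound 1 to compound 4 (0.18 log units; within the scatter), resting on the earlier step of a 1.5-fold higher number from compound 2 to compound 3 (0.17 log units; within the scatter) seen once among these compounds. Compound 4 is therefore estimated at 4200 nM in this assay, with a likely range from 2000 nM to 9000 nM.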

Compound 4, half-maximal inhibitory concentration: 4700 nM
For compound 4 the middle estimate is 1.1-fold (0.05 log units) below the measured one, and the stated range covers the measured number.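

In this assay, 1,1,2,2,2-pentafluoroethyl in place of pentafluorosulfanyl on the core of compound 1 gives a 1.7-fold higher number from compound 1 to compound 4 (0.22 log units; within the scatter), and the change carries between the two cores without a detectable difference: the same change on two cores in this assay, a 1.5-fold higher number (0.17 log units; within the scatter) from compound 2 to compound 3 and a 1.7-fold higher number (0.22 log units; within the scatter) from compound 1 to compound 4, 1.1-fold (0.06 log units) apart, within the scatter of two such steps

Both steps lie within the scatter, so neither core shows that this change moves the number at all. Agreement between two such small steps, from a single pair on each of two cores, does not show that the change would behave the same way on other cores.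

The compounds shown leave open whether a nitrile, an amine or a longer chain on the same aromatic carbon would move the number beyond the scatter. On these data alone, whether the step holds in other cell lines is also open.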